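The source may report more compounds than this note shows. Statements on the series, on what has been measured and on what is new or still open speak of the compounds shown alone.

Of the compounds shown here, two built on one shared core have been measured in a functional assay on A549 cells (Homo sapiens) for inhibition, read by sulforhodamine B assay, with a stated time of 48 h, tested at 10 uM; a higher number here means more inhibition at the concentration tested (going by the name of the read-out), a lower number less inhibition. Compound 1 `COc1ccc(-c2cn3ccnc3c(-c3ccc4ncn(C5CCCCC5)c4c3)n2)cc1` gives 68.6% in this assay. Compound 2 `Brc1ccc(-c2cn3ccnc3c(-c3ccc4ncn(C5CCCCC5)c4c3)n2)cc1` gives 15.3% in this assay. Among the measured compounds shown here, the only measured step joins these two: a number 53.3 percentage points lower from compound 1 to compound 2 (beyond the scatter). For the measured compounds named here, that step places compound 2 at the bottom of the two numbers in this assay, with compound 1 as its only neighbour, a clear distance above it.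

Compound 3 `COc1ccccc1-c1cn2ccnc2c(-c2ccc3ncn(C4CCCCC4)c3c2)n1` has not yet been measured. It differs from compound 2 in one place: 2-methoxyphenyl in place of 4-bromophenyl on an aromatic carbon. Going by the values given here, the single measured step bears directly on this change, since it shows that exchanging methoxy for bromo on that ring cost a large share of inhibition. Among the compounds with values here, compound 3 brings a methoxy back onto the same ring, though on a different carbon of it, so the reversal of that step is expected in direction; its size is less certain, as no measured compound carries the methoxy there. The expected step is a number 34.7 percentage points higher from compound 2 to compound 3 (beyond the scatter). Compound 3 is therefore estimated at 50% in this assay, within a range from 20% to 80%.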

Compound 3, a percentage reported as inhibition, at one concentration (the size of the read-out at that concentration, not a potency): 13.9%
Compound 3: the middle estimate sits 36.1 percentage points above what was measured; measured number outside the range, below it.
By their numbers in this assay, from the lowest: compounds 3 and 2 (each within the scatter of the next); then compound 1.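

In this assay, having a methoxy on this ring is clearly not enough on its own: 2-methoxyphenyl in place of 4-methoxyphenyl gives a number 54.7 percentage points lower from compound 1 to compound 3 (beyond the scatter) in a comparison that keeps the same group and changes only the ring carbon carrying it. Among the compounds shown here, the other comparison, 2-methoxyphenyl in place of 4-bromophenyl, gives a number 1.4 percentage points lower from compound 2 to compound 3 (within the scatter) and so does not separate these two compounds, which leaves the 4-methoxyphenyl of compound 1 as the only one of these three groups standing clearly apart. Nothing available here explains why the carbon that carries the methoxy matters so much.

The compounds shown leave open whether another small group on the same carbon as the methoxy of compound 1, such as a hydroxyl or an amine, would keep inhibition at that level, or whether the methoxy itself is needed. They also leave open whether moving the bromo of compound 2 to the carbon that carries the methoxy in compound 3 would change the number at all, and how any of these compounds would compare at other concentrations.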